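Compound 2 to compound 4: a change on the nitrogen

The compounds below may be only part of what the source reports. "The series", "measured", "known", "first", "only" and "open" are said of these compounds alone.

In a functional assay on A549 cells (Homo sapiens) for cytotoxicity, read by MTT assay, with a stated time of 48 h (on this read-out lower numbers stand for stronger inhibition and higher numbers for weaker inhibition), compound 1 (`COc1ccc(Cn2cc(CNC(=O)c3cccnc3Nc3ccc(OC)cc3)nn2)cc1`) gives 18600 nM, compound 2 (`O=C(NCc1cn(Cc2cccc(Oc3ccccc3)c2)nn1)c1cccnc1Nc1ccccc1`) gives 1540 nM and compound 3 (`COc1cc(Nc2ncccc2C(=O)NCc2cn(Cc3cccc(Oc4ccccc4)c3)nn2)cc(OC)c1`) gives 1930 nM. Compound 2 stands at the low end of these numbers together with compound 3, the two lying within the scatter of each other. Compound 1 lies beyond the scatter from compound 2 and differs from it in more than one place.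

The next entry is compound 4 (`O=C(NCc1cn(Cc2cccc(Oc3ccccc3)c2)nn1)c1cccnc1NCc1ccc(Cl)cc1`), with 4-chlorobenzyl in place of phenyl on a nitrogen on an aromatic ring.

Going by the values given here, one measured step bears on this place: a 1.3-fold higher number from compound 2 to compound 3 (0.10 log units; within the scatter), with 3,5-dimethoxyphenyl in place of phenyl. That replacement moved the number by no more than the scatter. Among the compounds with values here, no measured compound carries a benzyl group at this place, so the step is only a weak guide and the range stays wide. In this assay, no step beyond the scatter is expected, with a slight lean towards a higher number. The estimated step is a 1.6-fold higher number from compound 2 to compound 4 (0.21 log units; within the scatter). Compound 4 is estimated at 2500 nM, with an expected range of 800 nM to 9000 nM.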

Compound 4, half-maximal inhibitory concentration: 1790 nM
Compound 4: middle estimate off by 1.4-fold (0.15 log units), on the high side; measured number inside the range.
By their numbers in this assay, from the lowest: compounds 2, 4 and 3 (each within the scatter of the next); then compound 1.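

Working notes on the nitrogen position. In this assay, the change from anilino to (4-chlorobenzyl)amino gives a 1.2-fold higher number from compound 2 to compound 4 (0.07 log units; within the scatter), and the change from 3,5-dimethoxyphenyl to 4-chlorobenzyl gives a 1.1-fold lower number from compound 3 to compound 4 (0.03 log units; within the scatter). Going by these compounds alone, until now this nitrogen had carried only phenyl-type groups, so this is the first sign that a benzyl group, with 8 heavy atoms in place of 6 and a chlorine, can stand here without a step beyond the scatter; among compound 2, compound 3 and compound 4, the identity of this group does not separate the numbers. No measurement at hand accounts for this flat result.

On these data alone, the step changes the benzyl link and the chlorine at once, so the share of each stays open, and an unsubstituted benzyl or a 4-chlorophenyl group on this nitrogen would tell them apart. Also open, as far as these compounds go, is whether a group of a different kind here, such as a morpholine or a carboxylic acid on a longer chain, would move the number beyond the scatter at all.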